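This account rests on a few compounds, and the source may have more. Where it says the series, first, only, none or still open, it means among the compounds named here.

Compound 1 `CCn1c(/C=C2/C(=O)Nc3ccc(F)cc32)nc2ccccc21`: > 50000 nM (a limit of the assay)
Compound 2 `Cn1c(/C=C2/C(=O)Nc3ccc(Cl)cc32)nc2ccccc21`: 43600 nM

Both compounds were tested in a functional assay on HGC cells (Homo sapiens) for cytotoxicity, read by MTT assay, with a stated time of 48 h; a higher number here means a weaker inhibitor, a lower number a stronger inhibitor. Among the compounds with values here, compound 2, at 43600 nM, has the only true number here, and it marks a very weak inhibitor. Compound 1 gives > 50000 nM, which is a limit and not a number.

Compound 3 `CCn1c(/C=C2/C(=O)Nc3ccc(Cl)cc32)nc2ccccc21` differs from compound 2 in one place: methyl in place of hydrogen on a saturated chain carbon bound to an aromatic nitrogen. This puts methyl in place of hydrogen on a saturated chain carbon bound to an aromatic nitrogen, so methyl becomes ethyl. Within the data shown here, no measured pair shows this change alone, so there is little to suggest a shift in either direction. In this assay, no change beyond the usual scatter is expected, and the estimated step is a 1.0-fold lower number from compound 2 to compound 3 (0.02 log units; within the scatter). A result given only as a limit is also possible, given (the limit of > 50000 nM in this assay, at which 1 of the 2 values shown sits). For compound 3, the expected value is 42000 nM, within an estimated range of 20000 nM to 85000 nM.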

Compound 3, half-maximal inhibitory concentration: > 50000 nM
Compound 3: only a limit was reported (the forecaster's own chance of this, stated with the estimate: 40%); middle value at least 1.1-fold (0.07 log units) away from the limit.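

In this assay, within the data shown here, the first measured pair for methyl in place of hydrogen on a saturated chain carbon bound to an aromatic nitrogen gives an at least 1.1-fold higher number from compound 2 to compound 3 (0.05 log units; that floor lies within the scatter), so ethyl shows no sign of improving on methyl, while no real loss can be claimed either. Compound 3 gives > 50000 nM, which is a limit and not a number. The step between compound 1 and compound 3, chloro in place of fluoro on an aromatic carbon, cannot be read, since both results are limits, and limits now make up most of the set: the limit of > 50000 nM in this assay, at which 2 of the 3 values shown sit.

The compounds shown leave open how a longer chain such as propyl, or a chain ending in an amine or a carboxylic acid, would read at this position. They also leave open what bromo or methoxy in place of the chloro would give.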